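This account rests on a few compounds, and the source may have more. Where it says the series, first, only, none or still open, it means among the compounds named here.

Going by the values given here, in a functional assay on KB cells (Homo sapiens) for cytotoxicity (a lower number here means that less compound is needed, a higher number that more compound is needed for the effect), compound 1 `c1ccc(COc2cc(-c3ccccc3)nc3ccccc23)cc1` gives 1.6 ug/mL, the only true number so far. Compound 2 `Oc1cc(-c2ccccc2)nc2c(O)cccc12` reads > 10 ug/mL, which is a limit of this assay and not a number. With just these two readings, compound 1 has no measured neighbour to be compared with step by step.

Compound 3 `CS(=O)(=O)Oc1cc(-c2ccccc2)nc2ccccc12` keeps the core of compound 1 but has methylsulfonyl in place of benzyl on an oxygen on an aromatic ring. Among the compounds with values here, no measured step shows what this swap does, so any expectation is loose. The expected change in this assay is a moderate rise in the number, meaning that more compound would be needed. The estimated step is a 3.1-fold higher number from compound 1 to compound 3 (0.49 log units; beyond the scatter). For compound 3 the expected value is 5 ug/mL, with an estimated range from 1.5 ug/mL to 18 ug/mL.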

Compound 3, half-maximal effective concentration: 2.8 ug/mL
Compound 3: the middle estimate sits 1.8-fold (0.25 log units) above what was measured; the measured number falls inside the stated range.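

Swapping benzyl for methylsulfonyl on this oxygen gives a 1.8-fold higher number from compound 1 to compound 3 (0.24 log units; within the scatter), so in this assay the two compounds cannot be told apart. The swap removes an aromatic ring and brings in a group with no ring and with hydrogen-bond acceptors, yet the reading stays within the usual scatter; in this one pair, then, the benzyl ring is not needed for the effect. No measured property bears on why the two groups read alike.

As far as these compounds go, whether a group carrying an amine or a carboxylic acid, or a longer carbon chain, would read the same on this oxygen remains open. Going by these compounds alone, compound 2 reads > 10 ug/mL, which is a limit and not a number, and it differs from compound 1 in more than one place, so it gives no step.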